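A few compounds are considered here, and "the series" means these few. Any claim that something is new, unique, unknown or untested is made for them only; others in the source may bear on it.

Working notes on the series in a functional assay on Ehrlich cells (Mus musculus) for cytotoxicity, read by trypan blue exclusion, with a stated time of 2 h, tested at 10 ug/mL; a lower number here means a weaker effect, a higher number a stronger effect of the compound at the concentration tested. Among the measured compounds shown here, compound 1 `N#CC1=C(N)N(c2ccc(S(N)(=O)=O)cc2)C2=C(C(=O)CCC2)C1c1ccc(Cl)cc1Cl` gives 40%, the highest of the three numbers so far. Compound 2 `CC(Cl)CC(=O)NC1=C(C#N)C(c2ccc(Cl)cc2Cl)C2=C(CCCC2=O)N1c1ccc(S(N)(=O)=O)cc1` gives 20% and compound 3 `N#CC1=C(NC(=O)C2CC2)N(c2ccc(S(N)(=O)=O)cc2)C2=C(C(=O)CCC2)C1c1ccc(Cl)cc1Cl` gives 20%. The two measured changes both sit on the amine nitrogen: the step of a number 20 percentage points lower from compound 1 to compound 2 (beyond the scatter) came with (2-chloropropyl)carbonyl in place of hydrogen there, and the step of a number 20 percentage points lower from compound 1 to compound 3 (beyond the scatter) with cyclopropylcarbonyl in place of hydrogen. Between the two acylated compounds there is no change at the digits printed from compound 2 to compound 3 (within the scatter), with cyclopropyl in place of 2-chloropropyl on the carbonyl carbon.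

Compound 4 `NC1=C(C(=O)O)C(c2ccc(Cl)cc2Cl)C2=C(CCCC2=O)N1c1ccc(S(N)(=O)=O)cc1` is not yet measured. It differs from compound 1 as follows: carboxy in place of cyano on a double-bonded ring carbon. The amine nitrogen is untouched in this change, so none of the three measured steps bears on it; they concern another part of the shared core. For the measured compounds named here, there is no measured step at the double-bonded ring carbon from which to expect a size or direction, and the expectation must rest on compound 1 alone, with wide uncertainty. Compound 4 is expected to give about 30%, within 5% to 60%, which as a step means an estimated a number 10 percentage points lower from compound 1 to compound 4 (within the scatter).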

Compound 4, a percentage reported as activity, at one concentration (the size of the read-out at that concentration, not a potency): 0%
The estimate for compound 4 lay 30 percentage points above the measured number; the measured number lies below the stated range.
By their numbers in this assay, from the lowest: compound 4; then compounds 2 and 3 (each within the scatter of the next); then compound 1.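

In this assay, the double-bonded ring carbon bearing the cyano group proves sensitive to substitution: carboxy in place of cyano gives a number 40 percentage points lower from compound 1 to compound 4 (beyond the scatter), a step printed as large. The two measured changes on the amine nitrogen, a number 20 percentage points lower from compound 1 to compound 2 (beyond the scatter) and a number 20 percentage points lower from compound 1 to compound 3 (beyond the scatter), are printed as modest, so the series now has a large step at a second site on the shared core, and in this assay compound 4 reads 0%. No measurement at hand accounts for this step.

The compounds shown leave open whether the drop is specific to carboxy or would also follow other replacements for cyano on this carbon, such as a methyl ester, a primary carboxamide or a tetrazole. They also leave open how the cyclopropylcarbonyl or (2-chloropropyl)carbonyl group on the amine nitrogen would read in combination with a carboxy or other group in place of cyano, since each change is seen here only on its own.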